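The source may hold more compounds than are shown below. What is called first, only, known or untested is meant among the compounds shown, and "the series" means these compounds.

Working notes on the series. In an assay on HEK-293T cells for inhibition of diacylglycerol lipase-alpha (Homo sapiens), read by colorimetric assay (on this read-out higher numbers stand for weaker inhibition and lower numbers for stronger inhibition), compound 3 `CCC1CCCCN1C(=O)n1ncc(C(O)(c2ccccc2)c2ccccc2)n1` gives 63.1 nM, the highest number among the three measured compounds. In this assay compound 1 `O=C(N1C[C@@H](O)C=C[C@@H]1Cc1ccccc1)n1ncc(C(O)(c2ccc(F)cc2)c2ccc(F)cc2)n1` gives 20 nM and compound 2 `O=C(N1CCCCC1Cc1ccccc1)n1ncc(C(O)(c2ccc(F)cc2)c2ccc(F)cc2)n1` gives 1 nM; both numbers lie below that of compound 3, the gap to compound 2 being the wider one. Compound 4 `O=C(N1CCCCC1COc1ccccc1)n1ncc(C(O)(c2ccccc2)c2ccccc2)n1` is not yet measured and differs from compound 3 in one place: phenoxy in place of methyl on a saturated chain carbon bound to a saturated ring carbon. No such change has been measured within the series. A step toward a lower number is expected from compound 3 to compound 4, a 7.9-fold lower number from compound 3 to compound 4 (0.90 log units; beyond the scatter), because compound 2, which also carries an additional aromatic ring outside the shared core, gives 1 nM. Compound 4 is therefore estimated at 8 nM, with a range from 2 nM to 30 nM.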

Compound 4, half-maximal inhibitory concentration: 7.94 nM
The estimate for compound 4 lay 1.0-fold (0.00 log units) above the measured number; the range from low to high includes it.
By their numbers in this assay, from the lowest: compound 2; then compound 4; then compound 1; then compound 3.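

In this assay, a 7.9-fold lower number from compound 3 to compound 4 (0.90 log units; beyond the scatter) is a step beyond the scatter, so phenoxy in place of methyl on a saturated chain carbon bound to a saturated ring carbon goes with a lower number. The same difference reads ethyl to phenoxymethyl, so this step alone does not separate the contribution of the aromatic ring from that of the oxygen. No evidence bears on what lies behind the step. Left open is how propoxy, an oxygen-linked chain without an aromatic ring, or an amine at this place would compare with phenoxy.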